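The source may hold more compounds than are shown below. What is called first, only, known or untested is meant among the compounds shown, and "the series" means these compounds.

Values in a functional assay, read by fluorescence and spectrophotometry, with a stated time of 1 h (on this read-out higher numbers stand for an effect only at larger amounts of compound and lower numbers for an effect already at smaller amounts), so far:
- compound 1 `O=S(=O)(/C=C/c1ccc(O)c(O)c1)CC1CCCN1` gives 13800 nM
- compound 2 `CCCCCS(=O)(=O)/C=C/c1ccc(O)c(O)c1` gives 8100 nM

Compound 1 has a single neighbour on these numbers, compound 2, and the two lie within the scatter of each other. Compound 3 `CC(C)(C)OC(=O)N1CCCC1CS(=O)(=O)/C=C/c1ccc(O)c(O)c1` has yet to be measured. It differs from compound 1 by one change (tert-butoxycarbonyl in place of hydrogen on an amine nitrogen in a ring): tert-butoxycarbonyl in place of hydrogen on an amine nitrogen in a ring. Among the measured compounds shown here, the one measured step that bears on this (a 1.7-fold lower number from compound 1 to compound 2 (0.23 log units; within the scatter)) put butyl in place of pyrrolidin-2-yl on a saturated chain carbon bound to a sulfonyl sulfur. For the measured compounds named here, that step replaced the whole ring, so it is only an indirect guide, and no measured compound carries tert-butoxycarbonyl. No step beyond the scatter is therefore expected in this assay for this change, though with wide uncertainty. The estimate amounts to an expected step (a 1.4-fold lower number from compound 1 to compound 3 (0.14 log units; within the scatter)). Compound 3 is estimated at 10000 nM with an expected range (4000 nM to 25000 nM).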

Compound 3, half-maximal effective concentration: 7100 nM
Compound 3: middle estimate off by 1.4-fold (0.15 log units), on the high side, within the range that was stated.
By their numbers in this assay, from the lowest: compounds 3, 2 and 1 (each within the scatter of the next).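

Among the compounds shown here, until now, the only measured change at this part of compound 1 removed the whole ring, so nothing showed what a group on the ring nitrogen would do. In this assay, tert-butoxycarbonyl in place of hydrogen on the amine nitrogen in a ring gives a 1.9-fold lower number from compound 1 to compound 3 (0.29 log units; within the scatter), so even this large group, which leaves no hydrogen on that nitrogen, produces no step beyond the usual scatter. No measurement shown offers an explanation for this result.

The compounds shown leave open whether smaller groups on this nitrogen, such as methyl or acetyl, would also stay within the scatter. They also leave open whether a group with a ring, such as benzyl, or one with a carboxylic acid, would produce a clear step at this position.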